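The source may hold more compounds than are shown below. What is called first, only, known or untested is meant among the compounds shown, and "the series" means these compounds.

Measured compounds:
Compound 1 `COc1cccc(-c2csc(N/N=C/c3ccc4cc(OC)ccc4c3)n2)c1`: 56.7%
Compound 2 `COc1ccc(-c2csc(N/N=C/c3ccc4cc(OC)ccc4c3)n2)cc1`: 50%

Both numbers come from an assay on isolated protein for inhibition of Amine oxidase [flavin-containing] A (Homo sapiens), tested at 1 mM; on this read-out lower numbers stand for a stronger effect and higher numbers for a weaker effect at the one concentration tested. Compound 2 and compound 1 cannot be told apart on these numbers, since the step of a number 6.7 percentage points lower from compound 1 to compound 2 (within the scatter) lies within the scatter. Compound 3 `CCOC(=O)Cc1csc(N/N=C/c2ccc3cc(OC)ccc3c2)n1` is not yet measured; its change from compound 2 is (ethoxycarbonyl)methyl in place of 4-methoxyphenyl on an aromatic carbon. For the measured compounds named here, the single measured step concerns a different change and does not bear on this one, so no direction is supported and the estimate leans on the value of compound 2 alone, 50%, with a wide range. Compound 3 is expected to give 40%, between 15% and 65%. The expected step is a number 10 percentage points lower from compound 2 to compound 3 (within the scatter).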

Compound 3, a percentage reported as inhibition, at one concentration (the size of the read-out at that concentration, not a potency): 60.2%
Estimate against measurement, compound 3: 20.2 percentage points below; the measured number falls inside the stated range.
By their numbers in this assay, from the lowest: compounds 2, 1 and 3 (each within the scatter of the next, the first and the last beyond it).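

In this assay, the aromatic carbon that carried a methoxyphenyl group can also carry (ethoxycarbonyl)methyl, a group with no ring, and the read-out stays measurable. Replacing 4-methoxyphenyl gives a number 10.2 percentage points higher from compound 2 to compound 3 (beyond the scatter) and so a weaker effect, whereas replacing 3-methoxyphenyl gives a number 3.5 percentage points higher from compound 1 to compound 3 (within the scatter) and cannot be told apart from the scatter. Nothing available gives a reason for this result. The compounds shown leave open whether the ester itself matters, since a carboxylic acid or an amide could separate it from the chain length. A plain ethyl chain or an unsubstituted phenyl at this position would also help.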